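This account rests on a few compounds, and the source may have more. Where it says the series, first, only, none or still open, it means among the compounds named here.

Measured values in an ADME assay on RAW264.7 cells (Mus musculus) for cytotoxicity, read by MTT assay, with a stated time of 48 h; a higher number here means a weaker inhibitor, a lower number a stronger inhibitor:
Compound 1, `CCS(=O)(=O)Nc1ccc(NC(=O)c2ccc(C#N)cc2)cc1C`, gives 109000 nM.
Compound 2, `Cc1cc(NC(=O)c2ccc(Cl)cc2)ccc1NS(=O)(=O)C(F)(F)F`, gives 35400 nM.
Compound 3, `Cc1cc(NC(=O)c2ccc(C#N)cc2)ccc1NS(=O)(=O)C(F)(F)F`, gives 135000 nM.

Compound 3 carries the highest number of the three. Compound 1 stands closest to it: the step of a 1.2-fold higher number from compound 1 to compound 3 (0.09 log units; within the scatter), brought by trifluoromethyl in place of ethyl on a sulfonyl sulfur, does not leave the scatter. Compound 2 stands furthest away: the step of a 3.8-fold higher number from compound 2 to compound 3 (0.58 log units; beyond the scatter), brought by cyano in place of chloro on an aromatic carbon, is a modest one.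

Compound 4, `COc1cc(NC(=O)c2ccc(C#N)cc2)ccc1NS(=O)(=O)C(F)(F)F`, differs from compound 3 in one place: methoxy in place of methyl on an aromatic carbon. Neither measured step touches this position. One concerns the sulfonyl sulfur, the other the aromatic carbon that carries the cyano group; the carbon ortho to the ((trifluoromethyl)sulfonyl)amino group has not been varied among the measured compounds. Among the compounds with values here, no measured step therefore bears directly on the change, and the two that exist are small to modest. In this assay compound 4 is expected to show no shift beyond the scatter relative to compound 3. Compound 4 is estimated to give 130000 nM, with a range from 55000 nM to 300000 nM. This estimate means an expected step of a 1.0-fold lower number from compound 3 to compound 4 (0.02 log units; within the scatter).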

Compound 4, half-maximal inhibitory concentration: > 250000 nM
Compound 4 gave a limit, no number; the forecaster's own chance of this, stated with the estimate: 20%; at least 1.9-fold (0.28 log units) between middle value and limit.
By their numbers in this assay, from the lowest: compound 2; then compounds 1 and 3 (each within the scatter of the next). At a limit, above all of these: compound 4.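

In this assay compound 4 gives > 250000 nM, which is a limit of the assay and not a number. Within the data shown here, this is the first reading of a change on the aromatic carbon ortho to the ((trifluoromethyl)sulfonyl)amino group, and methoxy in place of methyl there gives an at least 1.8-fold higher number from compound 3 to compound 4 (0.26 log units; that floor lies within the scatter), so only a floor is known for the step, and that floor lies within the scatter. The change therefore moves the number upward or leaves it within the scatter, but gives no sign of a lower number in this assay, and the reading for this compound stands alone at the top of the set as an open-ended value: the limit of > 250000 nM in this assay, at which 1 of the 4 values shown sits.

As far as these compounds go, whether the true number for compound 4 lies just past this limit or far beyond it stays open, and so does the true size of the step. Also open, from the compounds shown here alone, is how other groups on this carbon, such as an amine, a hydroxyl or a longer ethoxy chain, would read, and whether methoxy would behave the same way with chloro in place of cyano, as in compound 2.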